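A few compounds are considered here, and "the series" means these few. Any claim that something is new, unique, unknown or untested is made for them only; others in the source may bear on it.

Series notes, values in a physicochemical assay for permeability, using PAMPA; on this read-out higher numbers stand for higher permeability and lower numbers for lower permeability:
- compound 1 `Cc1ccccc1-c1nc(CN2CCC(C(=O)NCCCN3CCC(C)(C)CC3)CC2)c(C)o1`: 241 10^-6 cm/s
- compound 2 `Cc1oc(-c2ccc(Cl)cc2)nc1CN1CCC(C(=O)NCCCN2C[C@H](C)C[C@H](C)C2)CC1`: > 635 10^-6 cm/s, a limit of the assay and not a number
- compound 3 `Cc1ccccc1-c1nc(CN2CCC(C(=O)NCCCN3CCCCC3)CC2)c(C)o1`: 34.5 10^-6 cm/s

Compound 3, with 34.5 10^-6 cm/s, holds the lowest of the two actual numbers in this assay. Compound 1 stands higher with 241 10^-6 cm/s. Going by the values given here, compound 2 has only a limit and differs from compound 3 in more than one place, so it provides no measured step here.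

Next is compound 4 `Cc1ccccc1-c1nc(CN2CCC(C(=O)NCCCN3CCCC(CC(C)C)C3)CC2)c(C)o1`, which carries isobutyl in place of hydrogen on a saturated ring carbon of the ring bearing the chain: isobutyl in place of hydrogen on a saturated ring carbon.

Among the compounds with values here, only one measured step bears on this change, and it involves substitution on that same ring: a 7.0-fold lower number from compound 1 to compound 3 (0.84 log units; beyond the scatter). That step is modest but beyond the scatter. Read in reverse, it points to a higher number when carbon substituents are present on this ring, although the group and its place differ in compound 4, so the transfer is uncertain. What is expected is a 6.7-fold higher number from compound 3 to compound 4 (0.82 log units; beyond the scatter), of similar size to the step from compound 1.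

For compound 4 the expected value is 230 10^-6 cm/s, with an estimated range from 80 10^-6 cm/s to 600 10^-6 cm/s.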

Compound 4, apparent permeability: 3 10^-6 cm/s
Beside the measured number, compound 4's estimate is 77-fold (1.88 log units) above it; measured number below the stated range.
By their numbers in this assay, from the lowest: compound 4; then compound 3; then compound 1. At a limit, above all of these: compound 2.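

In this assay, isobutyl in place of hydrogen on a saturated ring carbon, two ring bonds from the ring nitrogen, gives a 12-fold lower number from compound 3 to compound 4 (1.06 log units; beyond the scatter), whereas going from the 4,4-dimethylpiperidin-1-yl group to plain piperidin-1-yl gives a 7.0-fold lower number from compound 1 to compound 3 (0.84 log units; beyond the scatter). Added carbon on this ring therefore does not move the read-out in one direction: compound 1 lies higher than compound 3, and compound 4 lies lower. The two substituted rings also end far apart, with an 80-fold lower number from compound 1 to compound 4 (1.90 log units; beyond the scatter), and nothing shown here gives a measured cause for this reversal.

Going by these compounds alone, compound 2 gives > 635 10^-6 cm/s, which is a limit of the assay and not a number, and it provides no step that can be read. Still open, on these data alone, is whether the low value of compound 4 belongs to isobutyl itself or to its place on the ring, which a shorter group such as ethyl, or a hydroxymethyl group, an amine or a carboxylic acid on the same ring carbon, would help to separate.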